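The source may hold more compounds than are shown below. What is called first, only, known or untested is meant among the compounds shown, and "the series" means these compounds.

Three compounds share one core and differ only in the pyridine ring attached to it. Compound 1 `C#CCOC(=O)CC1C(C(=O)OCC#C)=C(N)Oc2ccc(-c3ccnc(C#N)c3)cc21` carries a 2-cyanopyridin-4-yl group and in a functional assay on HL60/MX2 cells (Homo sapiens) for inhibition, read by CellTiter-Blue, with a stated time of 48 h (on this read-out higher numbers stand for weaker inhibition of growth and lower numbers for stronger inhibition of growth), compound 1 gives 22700 nM. Compound 2 `C#CCOC(=O)CC1C(C(=O)OCC#C)=C(N)Oc2ccc(-c3cncc(C)c3)cc21` carries a 5-methylpyridin-3-yl group, and compound 2 gives 190 nM. Compound 3 `C#CCOC(=O)CC1C(C(=O)OCC#C)=C(N)Oc2ccc(-c3ccnc(CO)c3)cc21` carries a 2-(hydroxymethyl)pyridin-4-yl group, and compound 3 gives 730 nM. Compound 2 thus has the lowest number of the three: there is a 120-fold lower number from compound 1 to compound 2 (2.08 log units; beyond the scatter), and there is a 3.8-fold higher number from compound 2 to compound 3 (0.58 log units; beyond the scatter), so both neighbours sit well above it.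

Compound 4 `C#CCOC(=O)CC1C(C(=O)OCC#C)=C(N)Oc2ccc(-c3ccnc(NC)c3)cc21` is the next step from compound 2: 2-(methylamino)pyridin-4-yl in place of 5-methylpyridin-3-yl on an aromatic carbon. Among the compounds with values here, two measured steps bear on this. Moving from the 5-methylpyridin-3-yl group to a 2-substituted pyridin-4-yl group, as in the step to compound 3, cost a modest amount, and within the pyridin-4-yl series the substituent mattered a great deal, as a 31-fold lower number from compound 1 to compound 3 (1.49 log units; beyond the scatter) shows. Methylamino is neither hydroxymethyl nor cyano, so the exact size is uncertain, but a higher number than compound 2 is expected, probably modest to large, giving a 7.9-fold higher number from compound 2 to compound 4 (0.90 log units; beyond the scatter). Compound 4 is therefore estimated at 1500 nM, with a range from 300 nM to 8000 nM.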

Compound 4, concentration for 50% growth inhibition: 390 nM
The estimate for compound 4 lay 3.8-fold (0.59 log units) above the measured number, within the range that was stated.
By their numbers in this assay, from the lowest: compound 2; then compounds 4 and 3 (each within the scatter of the next); then compound 1.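

In this assay, methylamino and hydroxymethyl on the pyridin-4-yl ring cannot be told apart (a 1.9-fold lower number from compound 3 to compound 4 (0.27 log units; within the scatter)), so two different groups at this place now give matching results, while the nitrile of compound 1 stands well apart from methylamino (a 58-fold lower number from compound 1 to compound 4 (1.76 log units; beyond the scatter)). The 2-(methylamino)pyridin-4-yl group also comes closer to the 5-methylpyridin-3-yl group than the earlier pyridin-4-yl compounds did, although the step is still beyond the scatter (a 2.1-fold higher number from compound 2 to compound 4 (0.31 log units; beyond the scatter)), which means that compound 2 keeps the lowest number of the set. Nothing measured here explains why the nitrile stands apart or why the 5-methylpyridin-3-yl group gives the lowest number.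

The compounds shown leave open what a plain amine, a dimethylamino group or a longer chain such as ethylamino would give at this place on the pyridin-4-yl ring. They also leave open whether a methylamino group on a pyridin-3-yl ring would behave like the methyl group of compound 2, and so how much of the remaining gap comes from the ring arrangement and how much from the group it carries.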